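Compound 4: fluoro in place of nitro

This account rests on a few compounds, and the source may have more. Where it says the series, first, only, none or still open, it means among the compounds named here.

In a functional assay on MDA-MB-231 cells (Homo sapiens) for cytotoxicity, read by MTT assay, with a stated time of 96 h (on this read-out lower numbers stand for stronger inhibition and higher numbers for weaker inhibition), compound 2 `N=C(N)c1ccc(-c2ccc(-c3cccc([N+](=O)[O-])c3)o2)cc1` gives 2900 nM, within the scatter of compound 1 `CCc1ccc(-c2ccc(-c3ccc(C(=N)N)cc3)o2)cc1` at 3400 nM and compound 3 `CC(C)(C)c1ccc(-c2ccc(-c3ccc(C(=N)N)cc3)o2)cc1` at 3200 nM. Compound 4 `N=C(N)c1ccc(-c2ccc(-c3cccc(F)c3)o2)cc1` has fluoro in place of nitro on an aromatic carbon. Within the data shown here, no measured compound carries fluoro, so the evidence is indirect. Among the measured compounds shown here, the one measured step, a 1.1-fold lower number from compound 1 to compound 3 (0.03 log units; within the scatter), is tert-butyl in place of ethyl on an aromatic carbon and stays within the scatter. With that step and these three close values, no change beyond the scatter is expected in this assay. The expected step is a 1.0-fold higher number from compound 2 to compound 4 (0.01 log units; within the scatter). Compound 4 is estimated at 3000 nM, with an expected range of 1300 nM to 7000 nM.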

Compound 4, half-maximal inhibitory concentration: 2000 nM
Beside the measured number, compound 4's estimate is 1.5-fold (0.18 log units) above it; the measured number falls inside the stated range.
By their numbers in this assay, from the lowest: compounds 4, 2, 3 and 1 (each within the scatter of the next).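

In this assay, fluoro in place of nitro gives a 1.5-fold lower number from compound 2 to compound 4 (0.16 log units; within the scatter), so on this aromatic carbon, meta to a large group, a group of 3 heavy atoms gives way to one of 1 heavy atom with the read-out still within the scatter. The earlier step involved only alkyl groups, whereas this one shows that a nitrogen-and-oxygen group and a halogen can be exchanged here without a change beyond the scatter. No measurement available here accounts for the size of this step.

On these data alone, whether an amine or a carboxylic acid on this aromatic carbon would also stay within the scatter remains open. So does which single change, if any, would move this series beyond the scatter.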